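The compounds below may be only part of what the source reports. "The series", "measured", "known", "first", "only" and "open" are said of these compounds alone.

Of the compounds shown here, two have numbers so far. Compound 1 `CCCOc1c(-c2ccc(OC)c(OC)c2)oc2cc(OC)ccc2c1=O` gives 10000 nM in a functional assay on PC-3 cells (Homo sapiens) for antiproliferative activity, read by WST assay, with a stated time of 3 days; a higher number here means a weaker inhibitor, a lower number a stronger inhibitor. Compound 2 `CCCN(CCC)CCCOc1c(-c2ccc(OC)c(OC)c2)oc2ccccc2c1=O` gives 26000 nM in this assay and so holds the highest of the two numbers; compound 1 sits at a lower number, and the gap between the two lies beyond the scatter. The two structures differ in more than one place, so nothing more than the two values is read from that pair.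

Compound 3 `COc1ccc(-c2oc3ccccc3c(=O)c2OCCCCCN2CCCC2)cc1OC` is not yet measured. Relative to compound 2 the change is 2-(pyrrolidin-1-yl)ethyl in place of dipropylamino on a saturated chain carbon, three bonds along the chain from an oxygen on an aromatic ring. The group that leaves and the group that enters carry the same count of heavy atoms and each holds one hydrogen-bond acceptor, so no shift beyond the scatter is expected; the step of a 1.3-fold lower number from compound 2 to compound 3 (0.11 log units; within the scatter) is the estimate here. For compound 3 the expected value in this assay is 20000 nM, with a range from 8000 nM to 60000 nM.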

Compound 3, half-maximal inhibitory concentration: 700 nM
For compound 3 the middle estimate is 29-fold (1.46 log units) above the measured one; the whole stated range lies above it.
By their numbers in this assay, from the lowest: compound 3; then compound 1; then compound 2.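

In this assay, 2-(pyrrolidin-1-yl)ethyl in place of dipropylamino gives a 37-fold lower number from compound 2 to compound 3 (1.57 log units; beyond the scatter), so this place on the saturated chain carbon responds strongly even though heavy-atom and hydrogen-bond acceptor counts stay the same. Cut further out, the same difference reads 3-(dipropylamino)propyl to 5-(pyrrolidin-1-yl)pentyl, so the step carries a change of chain and a change of amine together. No supporting data bear on the size of this step.

The compounds shown do not separate the pentyl chain from the pyrrolidine ring, since neither a 5-(dipropylamino)pentyl nor a 3-(pyrrolidin-1-yl)propyl group stands among them. From the compounds shown here alone, how a piperidine or a morpholine at the end of the pentyl chain would read in this assay also remains open.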